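Bromophenyl Replacing Nitrooxyphenyl in a Hydrazone Series

The source may hold more compounds than are shown below. What is called first, only, known or untested is meant among the compounds shown, and "the series" means these compounds.

Measured compounds:
compound 1 `CN(C)CCn1cnnc1-c1cc(Oc2ccc(NC(=O)N/N=C/c3cc(C(C)(C)C)cc(C(C)(C)C)c3O)cc2F)ccn1` 680 nM
compound 2 `CN(C)CCn1cnnc1-c1cc(Oc2ccc(NC(=O)N/N=C/c3ccccc3O[N+](=O)[O-])cc2F)ccn1` 950 nM
compound 3 `Cn1ncnc1-c1cc(Oc2ccc(NC(=O)N/N=C/c3ccccc3)cc2F)ccn1` 30200 nM

In a functional assay on HT-29 cells (Homo sapiens) for cytotoxicity, read by MTT assay, with a stated time of 72 h (on this read-out lower numbers stand for stronger inhibition and higher numbers for weaker inhibition), compound 2 gives 950 nM, the second highest of the three numbers. Its nearest neighbour is compound 1, whose value lies within the scatter, while compound 3 stands far beyond it; compound 3 also differs from compound 2 in the core, so its gap is not a single step. Compound 4 `CN(C)CCn1cnnc1-c1cc(Oc2ccc(NC(=O)N/N=C/c3cccc(Br)c3)cc2F)ccn1` has not yet been measured. It differs from compound 2 by 3-bromophenyl in place of 2-(nitrooxy)phenyl on a carbon with a double bond to nitrogen. Going by the values given here, no measured pair isolates this change. A modest loss beyond the scatter is expected, a 2.6-fold higher number from compound 2 to compound 4 (0.42 log units; beyond the scatter), given that compound 3, which lacks the substituent on that ring, gives 30200 nM. Compound 4 is therefore estimated at 2500 nM, between 700 nM and 9000 nM.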

Compound 4, half-maximal inhibitory concentration: 380 nM
Beside the measured number, compound 4's estimate is 6.6-fold (0.82 log units) above it, and the stated range ends above it.
By their numbers in this assay, from the lowest: compounds 4, 1 and 2 (each within the scatter of the next, the first and the last beyond it); then compound 3.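

On the carbon with a double bond to nitrogen, 3-bromophenyl in place of 2-(nitrooxy)phenyl gives a 2.5-fold lower number from compound 2 to compound 4 (0.40 log units; beyond the scatter) in this assay. Going by these compounds alone, this is the first comparison that differs in one place, and it shows that activity at this position does not depend on the nitrooxy group, as the entering ring has no hydrogen-bond acceptors. Nothing measured here accounts for the step.

From the compounds shown here alone, it remains open whether the step follows the bromine itself or its place on the ring. Comparison with 2-bromophenyl, 3-chlorophenyl or 3-aminophenyl at this carbon would help separate the two.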